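Phenyl to pyridinyl on the best of three

A few compounds are considered here, and "the series" means these few. Any claim that something is new, unique, unknown or untested is made for them only; others in the source may bear on it.

Of the compounds shown here, three have been measured so far. Compound 1 `N#Cc1cnc(NCc2cnccc2C(F)(F)F)cc1N[C@H]1C[C@H](O)C1` gives 900 nM in an assay on isolated protein for inhibition of protein kinase C theta type (Homo sapiens), read by TR-FRET, with a stated time of 2 h; on this read-out higher numbers stand for weaker inhibition and lower numbers for stronger inhibition; compound 2 `CO[C@H]1CC[C@@H](CNc2cc(NCc3cnccc3C(F)(F)F)ncc2C#N)CC1` gives 70 nM in this assay; compound 3 `N#Cc1cnc(NCc2ccccc2C(F)(F)F)cc1N[C@H]1CC[C@@H](C(N)=O)CC1` gives 20 nM, the lowest number of the three, set apart from the others beyond the scatter. Among the compounds with values here, the one single-point step measured, a 13-fold lower number from compound 1 to compound 2 (1.11 log units; beyond the scatter), concerns the other substituent and does not touch the group changed here. Compound 4 `N#Cc1cnc(NCc2cnccc2C(F)(F)F)cc1N[C@H]1CC[C@@H](C(N)=O)CC1` is formed from compound 3 by the change (4-(trifluoromethyl)pyridin-3-yl in place of 2-(trifluoromethyl)phenyl on a saturated chain carbon bound to a nitrogen on an aromatic ring). Within the data shown here, compounds 1 and 2 already carry this pyridinyl group, but each also differs from compound 3 elsewhere, so their values show only that compounds bearing this pyridinyl group can reach low numbers in this assay without isolating the effect of the ring swap. Among the measured compounds shown here, with no step bearing directly on this change, a shift within or only modestly beyond the scatter is expected, leaning toward a slightly higher number, a 1.5-fold higher number from compound 3 to compound 4 (0.18 log units; within the scatter). Compound 4 is therefore estimated at 30 nM, in the range 10 nM to 90 nM.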

Compound 4, half-maximal inhibitory concentration: 7 nM
Estimate against measurement, compound 4: 4.3-fold (0.63 log units) above; the whole stated range lies above it.
By their numbers in this assay, from the lowest: compound 4; then compound 3; then compound 2; then compound 1.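

In this assay the ring swap now has a direct reading: with 4-carbamoylcyclohexyl held fixed, 4-(trifluoromethyl)pyridin-3-yl in place of 2-(trifluoromethyl)phenyl gives a lower number beyond the scatter (a 2.9-fold lower number from compound 3 to compound 4 (0.46 log units; beyond the scatter)). With the pyridinyl group held in common, 4-carbamoylcyclohexyl on the nitrogen also gives a lower number than either of the other two substituents (a 10-fold lower number from compound 2 to compound 4 (1.00 log units; beyond the scatter); a 130-fold lower number from compound 1 to compound 4 (2.11 log units; beyond the scatter)). No measurement shown here bears on the cause of these steps.

As far as these compounds go, whether the ring swap gives a similar step with 3-hydroxycyclobutyl or (4-methoxycyclohexyl)methyl on that nitrogen remains open. So does how an amine or a carboxylic acid in place of the carbamoyl group would read in this assay.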